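A Smaller Side Chain in Place of the Benzyl Ester

The source may hold more compounds than are shown below. What is called first, only, known or untested is meant among the compounds shown, and "the series" means these compounds.

Measured in a functional assay on the whole organism (Tail, strain ICR) with Mus musculus as the target, in the tail flick test, with a stated time of 120 min, at a dose of 25 umol/kg by the oral route; on this read-out lower numbers stand for a weaker effect and higher numbers for a stronger effect at the one dose given:
Compound 1 `N=C(N)NCCC[C@H](NC(=O)CN(c1ncnc2c1ncn2C1CCCCO1)C1CC1)C(=O)OCc1ccccc1` gives 38.2%.
Compound 2 `CC[C@H](C)[C@H](NC(=O)CN(c1ncnc2c1ncn2C1CCCCO1)C1CC1)C(=O)OCc1ccccc1` gives 20.4%.
Compound 3 `O=C(CN(c1ncnc2c1ncn2C1CCCCO1)C1CC1)N[C@@H](CCC(=O)OCc1ccccc1)C(=O)OCc1ccccc1` gives 20.7%.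

Compound 3 stands second highest of the three. Its nearest neighbour is compound 2, the step being a number 0.3 percentage points higher from compound 2 to compound 3 (within the scatter); the furthest is compound 1, with a number 17.5 percentage points lower from compound 1 to compound 3 (beyond the scatter).

Compound 4 `CC(C)C[C@H](NC(=O)CN(c1ncnc2c1ncn2C1CCCCO1)C1CC1)C(=O)OCc1ccccc1` differs from compound 3 in one place: isopropyl in place of (benzyloxycarbonyl)methyl on a saturated chain carbon, two bonds along the chain from an amide-type nitrogen and a carbonyl carbon. The step that bears on this is the one where a short alkyl side chain and the benzyl ester side chain were compared at this position, a number 0.3 percentage points higher from compound 2 to compound 3 (within the scatter), which lay within the scatter. The step from compound 3 to compound 4 is therefore expected to stay within the scatter as well: a number 0.3 percentage points higher from compound 3 to compound 4 (within the scatter). Compound 4 is estimated at 21%, expected to lie between 10% and 34%.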

Compound 4, a percentage reported as activity, at one dose (the size of the read-out at that dose, not a potency): 12.8%
Estimate against measurement, compound 4: 8.2 percentage points above; the range from low to high includes it.
By their numbers in this assay, from the lowest: compounds 4, 2 and 3 (each within the scatter of the next); then compound 1.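

In this assay, isobutyl at this position could not be told apart from either of the two larger side chains without nitrogen (a number 7.9 percentage points lower from compound 3 to compound 4 (within the scatter); a number 7.6 percentage points lower from compound 2 to compound 4 (within the scatter)). The side chain of compound 1 now stands apart from three such groups rather than two (a number 25.4 percentage points lower from compound 1 to compound 4 (beyond the scatter)). No available evidence explains these results. As far as these compounds go, whether the nitrogen atoms matter remains open: an amine or a shorter chain ending in the same nitrogen group might tell. A carboxylic acid in place of the benzyl ester also remains to be compared.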